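The source may hold more compounds than are shown below. What is called first, only, known or untested is meant among the compounds shown, and "the series" means these compounds.

Compound 3 `CC[C@@H]1/C=C(\C)C[C@H](C)C[C@H](OC)[C@H]2O[C@@](O)(C(=O)C(=O)N3CCCC[C@H]3C(=O)O[C@H](/C(C)=C/[C@@H]3CC[C@@H](Oc4ccc(OC)cc4)[C@H](OC)C3)[C@H](C)[C@@H](O)CC1=O)[C@H](C)C[C@@H]2OC` gives the lowest number of the three in a functional assay on cells for inhibition, with Murine T-cell line (Mus musculus) as the target (on this read-out lower numbers stand for stronger inhibition and higher numbers for weaker inhibition), at 1.4 nM. Compound 1 `CC[C@@H]1/C=C(\C)C[C@H](C)C[C@H](OC)[C@H]2O[C@@](O)(C(=O)C(=O)N3CCCC[C@H]3C(=O)O[C@H](/C(C)=C/[C@@H]3CC[C@@H](Oc4cccc(O)c4)[C@H](OC)C3)[C@H](C)[C@@H](O)CC1=O)[C@H](C)C[C@@H]2OC` gives 1.7 nM in this assay; the change a 1.2-fold lower number from compound 1 to compound 3 (0.08 log units; within the scatter) lies within the scatter. Compound 2 `CC[C@@H]1/C=C(\C)C[C@H](C)C[C@H](OC)[C@H]2O[C@@](O)(C(=O)C(=O)N3CCCC[C@H]3C(=O)O[C@H](/C(C)=C/[C@@H]3CC[C@@H](Oc4ccccc4)[C@H](O)C3)[C@H](C)[C@@H](O)CC1=O)[C@H](C)C[C@@H]2OC` gives 5.2 nM in this assay, beyond the scatter from compound 3, but it differs from compound 3 in two places, so no single step accounts for that gap. Compound 4 `CC[C@@H]1/C=C(\C)C[C@H](C)C[C@H](OC)[C@H]2O[C@@](O)(C(=O)C(=O)N3CCCC[C@H]3C(=O)O[C@H](/C(C)=C/[C@@H]3CC[C@@H](Oc4ccc(OC)cc4)[C@H](O)C3)[C@H](C)[C@@H](O)CC1=O)[C@H](C)C[C@@H]2OC` differs from compound 3 by hydrogen in place of methyl on an oxygen on a saturated carbon. Within the data shown here, no measured pair isolates exactly this change. Among the measured compounds shown here, compound 2, the only measured compound carrying hydroxy at that place, gives 5.2 nM, which hints at some weakening. Compound 4 is therefore expected to show a modest rise in number, a 2.1-fold higher number from compound 3 to compound 4 (0.33 log units; beyond the scatter), with an estimate of 3 nM in this assay and a range from 1.2 nM to 8 nM.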

Compound 4, half-maximal inhibitory concentration: 1.2 nM
Compound 4: middle estimate off by 2.5-fold (0.40 log units), on the high side; the measured number falls inside the stated range.
By their numbers in this assay, from the lowest: compounds 4, 3 and 1 (each within the scatter of the next); then compound 2.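

Replacing methyl with hydrogen on the oxygen on a saturated carbon, so that methoxy becomes hydroxy, gives a 1.2-fold lower number from compound 3 to compound 4 (0.07 log units; within the scatter) in this assay, so the hydroxy alone does not carry the weakening that compound 2 had hinted at. With hydroxy kept at that place, methoxy in place of hydrogen on an aromatic carbon gives a 4.3-fold lower number from compound 2 to compound 4 (0.64 log units; beyond the scatter), which places the gap to compound 2 on that aromatic change. Nothing at hand explains either result. Still open, on these data alone, is how a longer chain on that oxygen, or an amine in place of the hydroxy, would read in this assay.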